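Same atoms, flipped double bond: compound 3

A few compounds are considered here, and "the series" means these few. Any claim that something is new, unique, unknown or untested is made for them only; others in the source may bear on it.

Measured so far:
Compound 1 `C/C(=N/NC(=S)Nc1cccc([N+](=O)[O-])c1)c1ccccn1`: 38 nM
Compound 2 `C/C(=N/NC(=S)Nc1cccc(I)c1)c1ccccn1`: 45 nM

In a functional assay on MCF7 cells (Homo sapiens) for cytotoxicity, read by MTT assay, with a stated time of 48 h (a higher number here means a weaker inhibitor, a lower number a stronger inhibitor), compound 2 gives 45 nM, within the scatter of compound 1 at 38 nM. Compound 3 `C/C(=N\NC(=S)Nc1cccc(I)c1)c1ccccn1` is the next to be measured: the two compounds have the same atoms and bonds and differ only in configuration as drawn: 1 of 1 stereo elements differ; a double bond is drawn Z in compound 2 and E in compound 3. Among the compounds with values here, the only measured step is a 1.2-fold higher number from compound 1 to compound 2 (0.07 log units; within the scatter). It swaps one group for another and leaves the double bond alone, so it offers no direct guide to this change. No step beyond the scatter is expected in this assay, in either direction, though the uncertainty is wide. The expected change is a 1.2-fold higher number from compound 2 to compound 3 (0.09 log units; within the scatter). For compound 3 the estimate is 55 nM, with an expected range of 18 nM to 170 nM.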

Compound 3, half-maximal inhibitory concentration: 45 nM
Compound 3: the middle estimate sits 1.2-fold (0.09 log units) above what was measured, within the range that was stated.
By their numbers in this assay, from the lowest: compounds 1, 2 and 3 (each within the scatter of the next).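

In this assay the double bond gets its first direct test, which shows no change at the digits printed from compound 2 to compound 3 (within the scatter) with the iodo group in place. The earlier swap of nitro for iodo left this double bond untouched, so it could not show this. The comparison is a clean one, and it rests on a single point: the fact that compounds 2 and 3 differ only in the configuration as drawn

The compounds shown leave open whether the drawn configuration matters as little with the nitro group on the aromatic ring. They also leave open what an amine or a carboxylic acid there would give in either configuration.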